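This account rests on a few compounds, and the source may have more. Where it says the series, first, only, none or still open, it means among the compounds named here.

Of the compounds shown here, three sharing one core have been tested in a functional assay on T47D cells (Homo sapiens) for inhibition, read by sulforhodamine B assay, with a stated time of 48 h; on this read-out higher numbers stand for weaker inhibition of growth and lower numbers for stronger inhibition of growth. Compound 1 (`COc1cc(-c2nn(-c3cccc(NC(=O)c4cccc(C(F)(F)F)c4)c3)cc2-c2ccncc2)ccc1Cl`) gives 2550 nM, compound 2 (`COc1cc(-c2nn(-c3cccc(NC(=O)Nc4ccc(Cl)c(Cl)c4)c3)cc2-c2ccncc2)ccc1Cl`) gives 1420 nM, and compound 3 (`COc1cc(-c2nn(-c3cccc(NC(=O)c4ccc(Cl)c(C(F)(F)F)c4)c3)cc2-c2ccncc2)ccc1Cl`) gives 2050 nM. The numbers do not separate compound 3 from the other two, as the record shows a 1.4-fold higher number from compound 2 to compound 3 (0.16 log units; within the scatter) and also a 1.2-fold lower number from compound 1 to compound 3 (0.09 log units; within the scatter).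

Compound 4 (`COc1cc(-c2nn(-c3cccc(NC(=O)c4ccccc4)c3)cc2-c2ccncc2)ccc1Cl`) differs from compound 3 by phenyl in place of 4-chloro-3-(trifluoromethyl)phenyl on a carbonyl carbon. Part of this change has a measured counterpart, since chloro in place of hydrogen on an aromatic carbon gave the small step already cited. A larger exchange on the same carbonyl carbon gave a 1.8-fold lower number from compound 1 to compound 2 (0.25 log units; within the scatter). For the measured compounds named here, no measured step shows the trifluoromethyl group being lost, so that part remains untested. No step beyond the scatter is therefore expected in this assay, with only a slight lean towards a higher number. The expected step is a 1.3-fold higher number from compound 3 to compound 4 (0.12 log units; within the scatter). Compound 4 is estimated at 2700 nM, within an expected range of 1300 nM to 5500 nM.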

Compound 4, concentration for 50% growth inhibition: 1900 nM
Compound 4: the middle estimate sits 1.4-fold (0.15 log units) above what was measured; the range from low to high includes it.
By their numbers in this assay, from the lowest: compounds 2, 4, 3 and 1 (each within the scatter of the next).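

In this assay, the whole 4-chloro-3-(trifluoromethyl)phenyl gives way to plain phenyl on a carbonyl carbon with only a 1.1-fold lower number from compound 3 to compound 4 (0.03 log units; within the scatter), so neither the chloro nor the trifluoromethyl is needed to keep the number within the scatter. The loss of trifluoromethyl, previously without a measured step, now has one, a 1.3-fold lower number from compound 1 to compound 4 (0.13 log units; within the scatter), and phenyl in place of (3,4-dichlorophenyl)amino gives a 1.3-fold higher number from compound 2 to compound 4 (0.13 log units; within the scatter), so this position has so far tolerated every exchange shown without a step beyond the scatter. Nothing available bears on why these exchanges leave the number so little changed.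

The compounds shown leave open whether any group on this carbonyl carbon can move the number beyond the scatter. A longer alkyl chain in place of phenyl, or a phenyl carrying an amine or a carboxylic acid, could test that.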